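Hydroxy in place of ethoxy: expected clearance of compound 4

The source may report more compounds than this note shows. Statements on the series, on what has been measured and on what is new or still open speak of the compounds shown alone.

In an ADME assay on cells (Hepatocyte, Homo sapiens) for metabolic stability (a lower number here means slower removal, a higher number faster removal of the compound), compound 3 `CCOc1cc(-c2cnn(C)c2-c2sc3ccccc3c2C#N)cc2c(CN)n[nH]c(=O)c12` reads < 18 mL/min/kg and this is a limit of the assay, not a number.

Compound 1 `COCc1cc(-c2cnn(C)c2-c2sc3ccccc3c2C#N)cc2c(CN)n[nH]c(=O)c12` gives 66 mL/min/kg there and compound 2 `Cn1ncc(-c2cc(C(F)F)c3c(=O)[nH]nc(CN)c3c2)c1-c1sc2ccccc2c1C#N` gives 44 mL/min/kg in the same assay. These two sit close, with a 1.5-fold lower number from compound 1 to compound 2 (0.18 log units; within the scatter) as their step. The ethoxy group sets compound 3 apart from both, through an at least 3.6-fold lower number from compound 1 to compound 3 (0.56 log units; beyond the scatter) and through an at least 2.4-fold lower number from compound 2 to compound 3 (0.38 log units; beyond the scatter) as well.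

Compound 4 `Cn1ncc(-c2cc(O)c3c(=O)[nH]nc(CN)c3c2)c1-c1sc2ccccc2c1C#N` differs from compound 3 by hydrogen in place of ethyl on an oxygen on an aromatic ring and so turns ethoxy into hydroxy. Among the compounds with values here, no measured step shows this exact change, and the two ethoxy steps bear on it only indirectly. Among these three compounds only ethoxy gives the low reading, so removing the ethyl is expected to give back part of that gap, though not necessarily all of it.

The expected step is an at least 1.7-fold higher number from compound 3 to compound 4 (0.24 log units; that floor lies within the scatter) and its direction is towards faster removal, with its size uncertain.

Compound 4 is estimated at 32 mL/min/kg with 14 mL/min/kg to 70 mL/min/kg as the expected range in this assay and the measurement still to come.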

Compound 4, clearance: < 18 mL/min/kg
Compound 4 was reported as a limit; the forecaster's own chance of this, stated with the estimate: 20%; middle value at least 1.7-fold (0.24 log units) away from the limit.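

In this assay compound 4 gives < 18 mL/min/kg, and this is a limit of the assay, not a number. The low reading is therefore not tied to the ethyl on the oxygen on an aromatic ring: hydroxy also separates clearly from the other two groups, with an at least 2.4-fold lower number from compound 2 to compound 4 (0.38 log units; beyond the scatter) and with an at least 3.6-fold lower number from compound 1 to compound 4 (0.56 log units; beyond the scatter). The step between compound 3 and compound 4 cannot be read because both compounds rest at the same limit: the limit of < 18 mL/min/kg in this assay, at which 2 of the 4 values shown sit.

From the compounds shown here alone, how far the ethoxy and hydroxy compounds lie beyond that limit stays open, so the two groups cannot be ranked. Also open, going by these compounds, is whether an amine on the same aromatic carbon, or a longer chain such as propoxy, would keep the reading at the limit.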